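Cytotoxicity notes on the thiocarbamate series, compound 1 to 4

The source may report more compounds than this note shows. Statements on the series, on what has been measured and on what is new or still open speak of the compounds shown alone.

Measured so far in an ADME assay on MT4 cells (Homo sapiens) for cytotoxicity, read by MTT assay; a higher number here means that more compound is tolerated, a lower number that less compound is tolerated:
compound 1 `O=C1c2ccccc2C(=O)N1CCOC(=S)N(C(=O)c1ccc(C(F)(F)F)cc1)c1ccc(Cl)cc1` gives 10000 nM
compound 2 `O=C1c2ccccc2C(=O)N1CCOC(=S)N(C(=O)c1ccc(Cl)c(Cl)c1)c1ccccc1` gives 52000 nM
compound 3 `Cc1ccc(N(C(=O)c2ccc(Cl)cc2Cl)C(=S)OCCN2C(=O)c3ccccc3C2=O)cc1` gives 49000 nM

Compound 1 holds the lowest of the three numbers in this assay, so it is the least tolerated of the set; both compound 2 and compound 3 lie beyond the scatter above it, and the two of them sit close together. Going by the values given here, all three share the core of compound 1 and differ in the aromatic group on the carbonyl carbon and on the amide-type nitrogen, and no single-change pair among them has been measured, so the values only show where each stands.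

Compound 4 `O=C1c2ccccc2C(=O)N1CCOC(=S)N(C(=O)c1cc2ccccc2s1)c1ccc(Cl)cc1` is the next entry. Relative to compound 1 the change is 1-benzothiophen-2-yl in place of 4-(trifluoromethyl)phenyl on a carbonyl carbon. Among the compounds with values here, no measured step of this kind exists in the set, so the expectation rests on the spread seen so far. The step expected is a 2.0-fold higher number from compound 1 to compound 4 (0.30 log units; within the scatter), a small rise toward the region of compound 2 and compound 3, though a result within the scatter of compound 1 would not surprise. For compound 4 the estimate in this assay is 20000 nM, with a range from 7000 nM to 60000 nM.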

Compound 4, half-maximal cytotoxic concentration: 56000 nM
Estimate against measurement, compound 4: 2.8-fold (0.45 log units) below, and the stated range covers the measured number.
By their numbers in this assay, from the lowest: compound 1; then compounds 3, 2 and 4 (each within the scatter of the next).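

Going by these compounds alone, with the rest of the molecule unchanged, the group on the carbonyl carbon now gives the first single-place comparison: in this assay, 1-benzothiophen-2-yl in place of 4-(trifluoromethyl)phenyl gives a 5.6-fold higher number from compound 1 to compound 4 (0.75 log units; beyond the scatter) and the step is modest. The low number of compound 1 is therefore not fixed by the shared core and the group on the amide-type nitrogen alone, since this one change at the carbonyl carbon moves it beyond the scatter. Nothing at hand accounts for the size or direction of this step.

On these data alone, it remains open whether the step follows the departure of the trifluoromethyl group or the arrival of the fused ring, a question that a plain phenyl or a thiophen-2-yl on the same carbonyl carbon would address. Also open, as far as these compounds go, is whether the step holds with another group on the amide-type nitrogen, such as a methoxyphenyl.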